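Amide replacements of the amino group on the shared core

A few compounds are considered here, and "the series" means these few. Any claim that something is new, unique, unknown or untested is made for them only; others in the source may bear on it.

Of the compounds shown here, three have been measured in a functional assay on MCF7 cells (Homo sapiens) for inhibition, read by MTT assay, with a stated time of 48 h; on this read-out higher numbers stand for weaker inhibition and lower numbers for stronger inhibition. Compound 1 `COc1ccc(NC(=O)c2cc3cc(OC)c(OCCCOc4no[n+]([O-])c4S(=O)(=O)c4ccccc4)cc3oc2=O)cc1` gives 410 nM, compound 3 `COc1cc2cc(C(=O)Nc3ccccc3)c(=O)oc2cc1OCCCOc1no[n+]([O-])c1S(=O)(=O)c1ccccc1` gives 740 nM, and compound 2 `COc1cc2cc(N)c(=O)oc2cc1OCCCOc1no[n+]([O-])c1S(=O)(=O)c1ccccc1` gives 2020 nM, the highest number of the three; since its steps to both others lie beyond the scatter, compound 2 is the weakest inhibitor of the measured set. Compound 4 `COc1cc2cc(C(=O)Nc3ccc(F)cc3)c(=O)oc2cc1OCCCOc1no[n+]([O-])c1S(=O)(=O)c1ccccc1` has not been measured yet. It differs from compound 2 in one place: (4-fluorophenyl)carbamoyl in place of amino on an aromatic carbon. The step that bears most directly on this change is a 2.7-fold lower number from compound 2 to compound 3 (0.44 log units; beyond the scatter), the same exchange of the amino group for a carbamoyl group carrying an unsubstituted phenyl. A second reading of the same exchange, with methoxy on the aryl, is a 4.9-fold higher number from compound 1 to compound 2 (0.69 log units; beyond the scatter). Whether that aryl carries methoxy or hydrogen matters little, as a 1.8-fold higher number from compound 1 to compound 3 (0.26 log units; within the scatter) shows. The fluorine on the aryl of compound 4 is therefore expected to matter little as well, and the step from the amino compound is expected to go the same way as the other two. For compound 4 the expected step is a 3.4-fold lower number from compound 2 to compound 4 (0.53 log units; beyond the scatter). The estimate for compound 4 in this assay is 600 nM, with a range from 250 nM to 1500 nM.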

Compound 4, half-maximal inhibitory concentration: 860 nM
Estimate against measurement, compound 4: 1.4-fold (0.16 log units) below; low and high end bracket the measured number.
By their numbers in this assay, from the lowest: compounds 1, 3 and 4 (each within the scatter of the next, the first and the last beyond it); then compound 2.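

In this assay the exchange of amino for an aryl carbamoyl now has a third reading in a 2.3-fold lower number from compound 2 to compound 4 (0.37 log units; beyond the scatter) and runs the same way as the two earlier readings, so compound 1, compound 3 and compound 4 all lie on the same side of compound 2, with none of the three going against this. On the aryl, fluoro in place of hydrogen gives a 1.2-fold higher number from compound 3 to compound 4 (0.07 log units; within the scatter) and leaves the two compounds indistinguishable, so the phenylcarbamoyl and (4-fluorophenyl)carbamoyl groups cannot be told apart here. Fluoro in place of methoxy gives a 2.1-fold higher number from compound 1 to compound 4 (0.32 log units; beyond the scatter) and is the first aryl change in the series to pass the scatter, though only modestly, whereas hydrogen in place of methoxy stayed within it.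

Still open, as far as these compounds go, is whether the gain over amino needs an aryl ring at all, which a cyclohexylcarbamoyl group would test, and whether the amide hydrogen matters, which an N-methyl anilide would test, while a carboxylic acid or dimethylamino group on the aryl would show how far this substituent tolerance extends. Nothing available here accounts for the size or direction of any of these steps.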